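Chemokine receptor series: ethyl-linked aryl amide replaces fluorophenyl

The source may report more compounds than this note shows. Statements on the series, on what has been measured and on what is new or still open speak of the compounds shown alone.

Measured compounds:
compound 1 `Cc1ccc(CCC(=O)N[C@@H](C(=O)N2CCC(c3ccc(Cl)cc3)CC2)C(C)C)cc1` — 105 nM
compound 2 `CC(C)[C@@H](NC(=O)c1cc2ccccc2s1)C(=O)N1CCC(c2ccc(Cl)cc2)CC1` — 58 nM
compound 3 `CC(C)[C@@H](NC(=O)c1cccc(F)c1)C(=O)N1CCC(c2ccc(Cl)cc2)CC1` — 24 nM

All three share one core and differ only in the group on the carbonyl carbon next to the amide-type nitrogen. In an assay on THP-1 cells for displacement of a labelled ligand from C-C chemokine receptor type 1 (Homo sapiens) (on this read-out lower numbers stand for stronger inhibition and higher numbers for weaker inhibition), compound 3 gives 24 nM, the lowest number of the three; compound 2 sits at a 2.4-fold lower number from compound 2 to compound 3 (0.38 log units; beyond the scatter) and compound 1 at a 4.4-fold lower number from compound 1 to compound 3 (0.64 log units; beyond the scatter).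

Compound 4 `Cc1ccccc1CCC(=O)N[C@@H](C(=O)N1CCC(c2ccc(Cl)cc2)CC1)C(C)C` is not yet measured. Its change from compound 3: 2-(2-methylphenyl)ethyl in place of 3-fluorophenyl on a carbonyl carbon. Within the data shown here, the step that bears on this is the one from compound 1, which carries 2-(4-methylphenyl)ethyl at the same place, to compound 3: a 4.4-fold lower number from compound 1 to compound 3 (0.64 log units; beyond the scatter). Compound 4 carries 2-(2-methylphenyl)ethyl, and the data hold no direct comparison between 2-(4-methylphenyl)ethyl and 2-(2-methylphenyl)ethyl. Reversing that step is the expectation: compound 4 is expected to show a higher number than compound 3, roughly back near compound 1, an estimated 4.2-fold higher number from compound 3 to compound 4 (0.62 log units; beyond the scatter). The estimate for compound 4 in this assay is 100 nM, with a range from 40 nM to 250 nM.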

Compound 4, half-maximal inhibitory concentration: 19 nM
The estimate for compound 4 lay 5.3-fold (0.72 log units) above the measured number; the measured number lies below the stated range.
By their numbers in this assay, from the lowest: compounds 4 and 3 (each within the scatter of the next); then compounds 2 and 1 (each within the scatter of the next).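

In this assay, 2-methylphenyl in place of 4-methylphenyl on a saturated chain carbon, two bonds along the chain from a carbonyl carbon, gives a 5.5-fold lower number from compound 1 to compound 4 (0.74 log units; beyond the scatter), so the ethyl-linked aryl amide as such does not carry the higher number of compound 1; the place of the methyl on the ring matters. With 2-(2-methylphenyl)ethyl on the carbonyl carbon the series shows a 1.3-fold lower number from compound 3 to compound 4 (0.10 log units; within the scatter), so the ethyl-linked group and 3-fluorophenyl cannot be told apart here, while a 3.1-fold lower number from compound 2 to compound 4 (0.48 log units; beyond the scatter) sets it clear of 1-benzothiophen-2-yl. Nothing available explains the difference between the two methyl placements.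

The compounds shown leave open how 2-(3-methylphenyl)ethyl or 2-(2-chlorophenyl)ethyl would compare at this place. Also open, from the compounds shown here alone, is whether the result survives a shorter chain, as in 2-methylbenzyl, or an amine or carboxylic acid on the ring.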